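Cytotoxicity on THP-1 cells: amide variation in the series

A few compounds are considered here, and "the series" means these few. Any claim that something is new, unique, unknown or untested is made for them only; others in the source may bear on it.

Three compounds of the series have been run in a toxicity assay on THP-1 cells (Homo sapiens) for inhibition; a higher number here means that more compound is tolerated, a lower number that less compound is tolerated. Compound 1 `Cn1c(-c2ccccc2F)cnc1NC(=O)c1ccc(F)cc1` gives in this assay > 100000 nM, which is a limit of the assay rather than a number. Compound 2 `CCC(=O)Nc1ncc(-c2ccc(OC)cc2)n1C` likewise gives in this assay > 100000 nM, again a limit. Compound 3 `COc1ccc(-c2cnc(NC(=O)c3ccc(F)cc3)[nH]2)cc1` gives in this assay > 100000 nM, also a limit. Among the measured compounds shown here, compound 2 therefore stands at the limit of > 100000 nM in this assay, at which 3 of the 3 values shown sit; no compound of the set has yet produced a number in this assay, so no measured step between compounds exists.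

Compound 4 `COc1ccc(-c2cnc(NC(=O)c3ccc(C)cc3)n2C)cc1` remains to be measured in this assay. It differs from compound 2 by 4-methylphenyl in place of ethyl on a carbonyl carbon. The expected step of a number no higher from compound 2 to compound 4 (the limit leaves the size open) is none beyond the usual scatter, since compound 2 sits at the limit > 100000 nM and the other two compounds show the same limit. Compound 4 is therefore estimated at 100000 nM, with a range from 50000 nM to 200000 nM, and most likely the assay will again report only a limit for compound 4.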

Compound 4, half-maximal cytotoxic concentration: > 100000 nM
Compound 4 was reported as a limit; the forecaster's own chance of this, stated with the estimate: 85%; the middle value lies on the limit itself.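

Compound 2 and compound 4 are both reported only as limits, so no step can be read for 4-methylphenyl in place of ethyl on a carbonyl carbon. The compounds shown leave open whether any change in the series shifts tolerance in this assay, with every value still a limit: the limit of > 100000 nM in this assay, at which 4 of the 4 values shown sit.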